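The compounds below may be only part of what the source reports. "The series", "measured", "known", "first", "only" and "open" are said of these compounds alone.

Of the compounds shown here, two built on one shared core have been measured so far. In a functional assay on A549 cells (Homo sapiens) for cytotoxicity, read by MTT assay, with a stated time of 72 h (a higher number here means a weaker inhibitor, a lower number a stronger inhibitor), compound 2 `COc1ccc(/C=N/NC(=O)Nc2cc3c(Nc4ccc(F)c(Cl)c4)ncnc3cc2OC)cc1` gives 28100 nM, and compound 1 `CCN(CC)c1ccc(/C=N/NC(=O)Nc2cc3c(Nc4ccc(F)c(Cl)c4)ncnc3cc2O[C@H]2CCOC2)c(O)c1` gives 15700 nM. These two values lie within the usual scatter of each other, so compound 2 stands level with compound 1 on the numbers shown, and neither can be ranked ahead. The next compound is compound 3 `CCN(CC)c1ccc(/C=N/NC(=O)Nc2cc3c(Nc4ccc(F)c(Cl)c4)ncnc3cc2OC)c(O)c1`, which differs from compound 2 in one group: 4-(diethylamino)-2-hydroxyphenyl in place of 4-methoxyphenyl on a carbon with a double bond to nitrogen. In words, 4-(diethylamino)-2-hydroxyphenyl comes in place of 4-methoxyphenyl on a carbon with a double bond to nitrogen. Among the measured compounds shown here, no measured pair shows this swap on its own, so the size of the step in this assay has to be judged indirectly. The entering group also appears in compound 1, at 15700 nM, so a large move seems unlikely, and a slightly lower number, with no step beyond the scatter, is what is expected. The estimated change is a 1.6-fold lower number from compound 2 to compound 3 (0.19 log units; within the scatter). For compound 3 the estimated value is 18000 nM, with an expected range from 7000 nM to 45000 nM.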

Compound 3, half-maximal inhibitory concentration: 27300 nM
The estimate for compound 3 lay 1.5-fold (0.18 log units) below the measured number; the measured number falls inside the stated range.
By their numbers in this assay, from the lowest: compounds 1, 3 and 2 (each within the scatter of the next).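

In this assay, among the compounds shown here, 4-(diethylamino)-2-hydroxyphenyl in place of 4-methoxyphenyl on a carbon with a double bond to nitrogen gives a 1.0-fold lower number from compound 2 to compound 3 (0.01 log units; within the scatter) and so, seen on its own for the first time, this swap leaves the two compounds level within the scatter. The other place can now be read on its own too: methyl in place of oxolan-3-yl on an oxygen on an aromatic ring gives a 1.7-fold higher number from compound 1 to compound 3 (0.24 log units; within the scatter) and this step also stays within the scatter, so neither change separates the compounds in this assay. Nothing measured here offers an explanation for either result.

The entering group carries both a diethylamino and a hydroxy group, and the compounds shown do not tell whether either one alone, or a different group such as a carboxylic acid, would give a step beyond the scatter. On these data alone, on the oxygen on an aromatic ring, it also remains open whether a longer chain ending in an amine would move the number further than methyl or oxolan-3-yl.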